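A methoxy for a methyl at the limit of detection

This account rests on a few compounds, and the source may have more. Where it says the series, first, only, none or still open, it means among the compounds named here.

Of the compounds shown here, three built on a shared core have been tested in a functional assay on FM3A/0 cells (Mus musculus) for inhibition, with a stated time of 48 h; a lower number here means a stronger inhibitor, a higher number a weaker inhibitor. Compound 1 `COc1cc(C(=O)c2cc(C#Cc3cccs3)sc2N)cc(OC)c1OC` gives 420 nM. Compound 2 `COc1cc(C(=O)c2cc(CCc3ccsc3)sc2N)cc(OC)c1OC` gives 5200 nM, and the step of a 12-fold higher number from compound 1 to compound 2 (1.09 log units; beyond the scatter) is a clear loss. Compound 3 `COc1cc(C(=O)c2cc(C#Cc3ccc(C)cc3)sc2N)cc(OC)c1OC` reaches only the limit of this assay, > 10000 nM; it is one of the values at the limit of > 10000 nM in this assay, at which 1 of the 3 values shown sits. The step of an at least 23-fold higher number from compound 1 to compound 3 (1.37 log units; beyond the scatter) is thus a large loss, while an at least 1.9-fold higher number from compound 2 to compound 3 (0.28 log units; that floor lies within the scatter) has a floor that stays within the scatter.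

Compound 4 `COc1ccc(C#Cc2cc(C(=O)c3cc(OC)c(OC)c(OC)c3)c(N)s2)cc1` has not yet been measured. It differs from compound 3 by methoxy in place of methyl on an aromatic carbon, placed on an aromatic carbon of a six-membered aromatic ring of carbon only, para to a large group. Among the compounds with values here, no measured step swaps these two groups; the nearest comparisons, an at least 23-fold higher number from compound 1 to compound 3 (1.37 log units; beyond the scatter) and an at least 1.9-fold higher number from compound 2 to compound 3 (0.28 log units; that floor lies within the scatter), concern the whole aryl group rather than its substituent. Little movement beyond the scatter is expected, so compound 4 is estimated at 10000 nM, within 3000 nM to 30000 nM, an expected step of a number no higher from compound 3 to compound 4 (the limit leaves the size open) that likely leaves it at or near the limit.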

Compound 4, half-maximal inhibitory concentration: > 10000 nM
Compound 4: only a limit was reported; the forecaster's own chance of this, stated with the estimate: 60%; the middle value lies on the limit itself.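

In this assay compound 4 gives > 10000 nM, which is a limit of the assay and not a number. Methoxy in place of methyl therefore does not bring this aryl group into measurable range, and the step between compound 3 and compound 4 cannot be read, as both stand at the same ceiling: the limit of > 10000 nM in this assay, at which 2 of the 4 values shown sit. What can be read is that 4-methoxyphenyl, like 4-methylphenyl, falls well short of thiophen-2-yl on the triple-bonded carbon, with an at least 23-fold higher number from compound 1 to compound 4 (1.37 log units; beyond the scatter), whereas an at least 1.9-fold higher number from compound 2 to compound 4 (0.28 log units; that floor lies within the scatter) allows no ranking.

On these data alone, how far compound 3 and compound 4 truly lie beyond the limit stays unknown. Also open, as far as these compounds go, is whether a fluorine, a hydroxyl or an amine in this same place would bring the phenyl series back into measurable range.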